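A Chloro Added to a Butylene-Linked Sulfonyl Fluoride

The compounds below may be only part of what the source reports. "The series", "measured", "known", "first", "only" and "open" are said of these compounds alone.

Among the compounds with values here, compound 2 `CC1(C)N=C(N)N=C(N)N1c1cccc(OCCCCOc2ccc(S(=O)(=O)F)cc2)c1` is one of two compounds measured in an assay on isolated protein for inhibition of Dihydrofolate reductase (Mus musculus); a higher number here means a more potent compound, by a factor of ten per unit of this negative logarithm, a lower number a less potent compound. In this assay compound 2 gives 7.49, the highest of the two numbers; in this assay compound 1 `CC1(C)N=C(N)N=C(N)N1c1ccc(OCc2ccccc2C(=O)Nc2ccc(S(=O)(=O)F)cc2)c(Cl)c1` gives 7.24, a value within the scatter of that of compound 2. Compound 3 `CC1(C)N=C(N)N=C(N)N1c1ccc(Cl)c(OCCCCOc2ccc(S(=O)(=O)F)cc2)c1` differs from compound 2 in one place: chloro in place of hydrogen on an aromatic carbon. Within the data shown here, no step between measured compounds shows what such a change does here, so little movement beyond the scatter is expected, and the estimated step of a number 0.11 log units higher from compound 2 to compound 3 (within the scatter) is small. In this assay compound 3 is expected to give 7.6, in a range from 7 to 8.2.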

Compound 3, logarithm of the reciprocal of the active concentration, log(1/C): 7.17
Compound 3: middle estimate off by 0.43 log units, on the high side, within the range that was stated.
By their numbers in this assay, from the lowest: compounds 3, 1 and 2 (each within the scatter of the next, the first and the last beyond it).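

Putting chloro in place of hydrogen on this aromatic carbon, ortho to a large group and para to a large group, gives in this assay a number 0.32 log units lower from compound 2 to compound 3 (beyond the scatter). Within the data shown here, this is the first single change that can be read here, and it shows that this position does not accept the added chlorine without a modest loss. Nothing available accounts for the step. On these data alone, whether the loss belongs to chloro alone remains open, as fluoro, methyl or methoxy on the same carbon would show. As far as these compounds go, it is also open whether the step would hold with a longer chain.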